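Cytotoxicity limits across fluorophenyl and methylphenyl propyl analogues

The source may hold more compounds than are shown below. What is called first, only, known or untested is meant among the compounds shown, and "the series" means these compounds.

Compound 1 `Cc1nc2c(c(-c3cc(F)c4c(c3C)CCCO4)c1[C@H](OC(C)(C)C)C(=O)O)CN(CCCc1cccc(F)c1)CC2`, compound 2 `Cc1cccc(CCCN2CCc3nc(C)c([C@H](OC(C)(C)C)C(=O)O)c(-c4cc(F)c5c(c4C)CCCO5)c3C2)c1` and compound 3 `Cc1nc2c(c(-c3cc(F)c4c(c3C)CCCO4)c1[C@H](OC(C)(C)C)C(=O)O)CN(CCCc1ccccc1F)CC2` share one core and differ only in the aryl group carried on the propyl chain of the ring amine. In an ADME assay on MT2 cells (Homo sapiens) for cytotoxicity, read by XTT assay, with a stated time of 4 days (a lower number here means that less compound is tolerated, a higher number that more compound is tolerated), compound 1 gives > 40000 nM, which is a limit of the assay and not a number. In this assay compound 2 gives > 40000 nM, likewise a limit. In this assay compound 3 gives > 40000 nM, again a limit. The change from compound 1 to compound 2 is methyl in place of fluoro on an aromatic carbon; its step is a step that the two limits leave unreadable from compound 1 to compound 2, since both ends sit at the limit of > 40000 nM in this assay, at which 3 of the 3 values shown sit. Compound 3 differs from compound 1 by 2-fluorophenyl in place of 3-fluorophenyl on a saturated chain carbon, three bonds along the chain from an amine nitrogen in a ring. Compound 4 `Cc1ccccc1CCCN1CCc2nc(C)c([C@H](OC(C)(C)C)C(=O)O)c(-c3cc(F)c4c(c3C)CCCO4)c2C1` is not yet measured; it differs from compound 3 by methyl in place of fluoro on an aromatic carbon. This is the same kind of change as from compound 1 to compound 2, not the same: there the place is meta to a large group, here it is ortho to a large group. The expected step in this assay is a step that the limit leaves unreadable from compound 3 to compound 4, because every measured value sits at the limit of > 40000 nM in this assay, at which 3 of the 3 values shown sit. For compound 4 the estimate in this assay is 50000 nM, with a range from 30000 nM to 120000 nM.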

Compound 4, half-maximal cytotoxic concentration: > 40000 nM
Compound 4 gave a limit, no number (the forecaster's own chance of this, stated with the estimate: 85%); the middle value does not contradict the limit.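

In this assay no step can be read among compound 1, compound 2, compound 3 and compound 4, because each gives a limit and not a number: the limit of > 40000 nM in this assay, at which 4 of the 4 values shown sit.

The compounds shown leave open at what concentration, if any, compound 1, compound 2, compound 3 or compound 4 would reach a half-maximal cytotoxic effect, and whether the aryl groups differ.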